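The source may report more compounds than this note shows. Statements on the series, on what has been measured and on what is new or still open speak of the compounds shown alone.

Compound 1 `COc1cc(-c2cc(/C=C/C(=O)c3ccc(N)cc3)[nH]n2)cc(OC)c1OC` carries the higher of the two numbers in hand: in a functional assay on MDA-MB-468 cells (Homo sapiens) for inhibition, read by sulforhodamine B assay, with a stated time of 48 h (on this read-out higher numbers stand for weaker inhibition of growth and lower numbers for stronger inhibition of growth), compound 1 gives 1010 nM. Compound 2 `COc1ccc(-c2cc(/C=C/C(=O)c3ccc(N)cc3)[nH]n2)cc1`, which differs from it elsewhere in the molecule, gives in this assay compound 2 430 nM, a lower number and beyond the scatter. Compound 3 `COc1ccc(C(=O)/C=C/c2cc(-c3cc(OC)c(OC)c(OC)c3)n[nH]2)cc1OC` keeps the rest of compound 1 and alters the end bearing the carbonyl: 3,4-dimethoxyphenyl in place of 4-aminophenyl on a carbonyl carbon. Among the compounds with values here, no measured pair shows this change, so its direction is open; the expected step is a 1.0-fold lower number from compound 1 to compound 3 (0.00 log units; within the scatter), none beyond the scatter. Compound 3 is accordingly estimated at 1000 nM, within 300 nM to 3500 nM.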

Compound 3, concentration for 50% growth inhibition: 750 nM
Beside the measured number, compound 3's estimate is 1.3-fold (0.12 log units) above it; measured number inside the range.
By their numbers in this assay, from the lowest: compounds 2, 3 and 1 (each within the scatter of the next, the first and the last beyond it).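

Working in this assay, the carbonyl carbon accepts 3,4-dimethoxyphenyl in place of 4-aminophenyl with a 1.3-fold lower number from compound 1 to compound 3 (0.13 log units; within the scatter). On the core of compound 1, this end therefore carries a larger group with no hydrogen-bond donor and the read-out does not separate the two compounds. No supporting data bear on why this is so.

Open, going by these compounds, is whether a carboxylic acid or a plain phenyl at this place would hold the same level. Also open, on these data alone, is whether the same change holds on the core of compound 2.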